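Pyrazoline series on HeLa cells: bromo to methyl change

A few compounds are considered here, and "the series" means these few. Any claim that something is new, unique, unknown or untested is made for them only; others in the source may bear on it.

Measured so far, in a functional assay on HeLa cells (Homo sapiens) for inhibition, read by CCK-8 assay, with a stated time of 48 h; on this read-out lower numbers stand for stronger inhibition and higher numbers for weaker inhibition:
compound 1 `Cc1ccc(C2=NN(C3=NC(c4ccccc4)CS3)C(c3ccc4ccccc4c3)C2)cc1` gives 2460 nM
compound 2 `Brc1ccc(C2=NN(C3=NC(c4ccccc4)CS3)C(c3ccc4ccccc4c3)C2)cc1` gives 4960 nM
compound 3 `O=C1CSC(N2N=C(c3ccc(Br)cc3)CC2c2cccc3ccccc23)=N1` gives 5810 nM

Compound 1 and compound 2 share a core and differ by methyl in place of bromo on an aromatic carbon; this change gave a 2.0-fold lower number from compound 2 to compound 1 (0.30 log units; within the scatter). Compound 3 carries another core; the difference between the two cores of compound 2 and compound 3 is not broken down here. The numbers for compound 2 and compound 3 lie within the scatter of each other.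

Compound 4 `Cc1ccc(C2=NN(C3=NC(=O)CS3)C(c3cccc4ccccc34)C2)cc1` is compound 3 with the same change, (methyl in place of bromo on an aromatic carbon), made on the core of compound 3. In this assay the step from compound 3 to compound 4 is expected to be a 1.9-fold lower number from compound 3 to compound 4 (0.29 log units; within the scatter), because the same change gave a 2.0-fold lower number from compound 2 to compound 1 (0.30 log units; within the scatter) on the other core, and nothing more is known of how it behaves here. Compound 4 is therefore estimated at 3000 nM, with a range from 1500 nM to 6000 nM.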

Compound 4, half-maximal inhibitory concentration: 3210 nM
The estimate for compound 4 lay 1.1-fold (0.03 log units) below the measured number; low and high end bracket the measured number.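

In this assay, methyl in place of bromo on the core of compound 3 gives a 1.8-fold lower number from compound 3 to compound 4 (0.26 log units; within the scatter), and this step agrees with the one on the other core: the same change on two cores in this assay, a 2.0-fold lower number (0.30 log units; within the scatter) from compound 2 to compound 1 and a 1.8-fold lower number (0.26 log units; within the scatter) from compound 3 to compound 4, 1.1-fold (0.05 log units) apart, within the scatter of two such steps

Across these two pairs, 4-bromophenyl to 4-methylphenyl therefore reads alike on both cores. For the compounds shown here, each step lies within the scatter, however, so the agreement shows only that neither core gives a step beyond it, not that a real shift in the number carries from one core to the other.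

As far as these compounds go, it remains open whether another group in this place, such as an amine, a carboxylic acid or a longer chain, would move the number beyond the scatter on either core. From the compounds shown here alone, it also remains open whether such a step would carry across the two cores as this one does.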